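The compounds below may be only part of what the source reports. "The series", "measured", "known", "first", "only" and "open" are said of these compounds alone.

In an ADME assay on NIH3T3 cells (Mus musculus) for inhibition, read by sulforhodamine B assay, with a stated time of 48 h (on this read-out lower numbers stand for stronger inhibition of growth and higher numbers for weaker inhibition of growth), compound 1 `COc1cccc(C(=O)NNC(=O)c2ccc3[nH]c(-c4ccc([N+](=O)[O-])o4)nc3c2)c1` gives 15.6 ug/mL and compound 3 `O=C(NNC(=O)c1cc2ccccc2cc1O)c1ccc2[nH]c(-c3ccc([N+](=O)[O-])s3)nc2c1` gives 31.3 ug/mL, so the two lie within the scatter of each other. Compound 2 `O=C(NNC(=O)c1ccc2[nH]c(-c3ccc([N+](=O)[O-])o3)nc2c1)c1cccc(Oc2ccccc2)c1` gives only a limit, > 7.8 ug/mL. Compound 4 `COc1ccc(C(=O)NNC(=O)c2ccc3[nH]c(-c4ccc([N+](=O)[O-])o4)nc3c2)cc1OC` differs from compound 1 by a single change, (methoxy in place of hydrogen on an aromatic carbon), with methoxy in place of hydrogen on an aromatic carbon, turning 3-methoxyphenyl into 3,4-dimethoxyphenyl. Within the data shown here, the only measured step that bears on this is a step that the limit leaves unreadable from compound 1 to compound 2, and it offers no size to carry over. No step beyond the scatter is therefore expected in this assay, and the value of compound 1, 15.6 ug/mL, remains the anchor. The estimate for compound 4 is 15 ug/mL, with an expected range from 6 ug/mL to 40 ug/mL. The expected change is a 1.0-fold lower number from compound 1 to compound 4 (0.02 log units; within the scatter).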

Compound 4, concentration for 50% growth inhibition: 31.3 ug/mL
The estimate for compound 4 lay 2.1-fold (0.32 log units) below the measured number; the measured number falls inside the stated range.
By their numbers in this assay, from the lowest: compounds 1, 3 and 4 (each within the scatter of the next).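

In this assay, among these compounds, turning 3-methoxyphenyl into 3,4-dimethoxyphenyl, with the new methoxy ortho to a methoxy group and para to a large group, gives a 2.0-fold higher number from compound 1 to compound 4 (0.30 log units; within the scatter) and is the first step on this ring that can be read. This position therefore takes a methoxy group without a change beyond the scatter. Nothing measured among these compounds accounts for this step. From the compounds shown here alone, whether an amine, a carboxylic acid or a fluorine on the same carbon would behave alike stays open, as does the effect of a longer chain on the oxygen.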